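A few compounds are considered here, and "the series" means these few. Any claim that something is new, unique, unknown or untested is made for them only; others in the source may bear on it.

Compound 1 `O=[N+]([O-])c1ccccc1Nc1nnc(-c2c[nH]c3ccccc23)o1`: 850 nM
Compound 2 `O=[N+]([O-])c1cccc(Nc2nnc(-c3c[nH]c4ccccc34)o2)c1`: 25500 nM
Compound 3 `O=[N+]([O-])c1ccc(Nc2nnc(-c3c[nH]c4ccccc34)o2)cc1`: 890 nM

In a functional assay on KG-1a cells (Homo sapiens) for inhibition, with a stated time of 24 h (a higher number here means a weaker inhibitor, a lower number a stronger inhibitor), compound 3 gives 890 nM. This is level with compound 1 at 850 nM, the two lying within the scatter of each other. Compound 2 gives a much higher number, 25500 nM, well beyond the scatter from compound 3.

Compound 4 `Fc1ccc(Nc2nnc(-c3c[nH]c4ccccc34)o2)cc1` has not yet been measured. It carries fluoro in place of nitro on an aromatic carbon, para to a large group (fluoro in place of nitro on an aromatic carbon). Going by the values given here, no measured pair here shows what such a replacement does, and every measured compound carries nitro, so the expectation is loose. Among the compounds with values here, the three values show only that the number can differ widely among close relatives, as compound 2 at 25500 nM makes plain. A moderate rise in this assay is expected, towards weaker inhibition and probably beyond the scatter.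

The estimated step is a 2.8-fold higher number from compound 3 to compound 4 (0.45 log units; beyond the scatter).

For compound 4, the estimated value is 2500 nM, with an expected range of 500 nM to 15000 nM.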

Compound 4, half-maximal inhibitory concentration: 21100 nM
Compound 4: the middle estimate sits 8.4-fold (0.93 log units) below what was measured; the measured number lies above the stated range.
By their numbers in this assay, from the lowest: compounds 1 and 3 (each within the scatter of the next); then compounds 4 and 2 (each within the scatter of the next).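

In this assay, going by these compounds alone, fluoro in place of nitro on this aromatic carbon, para to a large group, gives a 24-fold higher number from compound 3 to compound 4 (1.37 log units; beyond the scatter), a step the earlier compounds could not show because all of them carry nitro. With the rest of the structure unchanged, the group at this place can alone produce a large change, and of these two groups nitro goes with the stronger inhibition. Nothing measured here accounts for the step.

As far as these compounds go, it remains open whether nitro is specifically favoured at this place or fluoro specifically disfavoured; a nitrile, an amine or a carboxylic acid on the same carbon would help separate these readings. The compounds shown also leave open how fluoro would fare elsewhere on this ring, as it appears at this place only.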